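From 2-Fluorophenyl to 4-(Trifluoromethyl)phenyl on the Shared Core

This account rests on a few compounds, and the source may have more. Where it says the series, first, only, none or still open, it means among the compounds named here.

Within the data shown here, compound 2 `Cc1nc(-c2ccccc2F)sc1COc1ccc2c(c1)OCC2CC(=O)O` gives 25.8% in a functional assay on CHO cells for agonist activity at Free fatty acid receptor 1 (Homo sapiens), read by FLIPR and calcium flux, tested at 100 nM (on this read-out lower numbers stand for a weaker effect and higher numbers for a stronger effect at the one concentration tested), the higher of the two numbers measured so far, while compound 1 `Cc1nc(-c2ccc(Cl)s2)sc1COc1ccc2c(c1)OCC2CC(=O)O` gives 8.34%. Among the measured compounds shown here, the only measured step, a number 17.5 percentage points higher from compound 1 to compound 2 (beyond the scatter), concerns a different exchange of aryl groups and bears only loosely on the present one. Compound 3 `Cc1nc(-c2ccc(C(F)(F)F)cc2)sc1COc1ccc2c(c1)OCC2CC(=O)O` differs from compound 2 by 4-(trifluoromethyl)phenyl in place of 2-fluorophenyl on an aromatic carbon. Lacking a directly comparable step, a change of at most modest size is expected. Compound 3 is therefore estimated at 20%, with a range from 3% to 45%. This estimate corresponds to an expected step of a number 5.8 percentage points lower from compound 2 to compound 3 (within the scatter).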

Compound 3, a percentage reported as activity, at one concentration (the size of the read-out at that concentration, not a potency): 50.4%
Compound 3: the middle estimate sits 30.4 percentage points below what was measured; the whole stated range lies below it.
By their numbers in this assay, from the lowest: compound 1; then compound 2; then compound 3.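

In this assay the exchange at this aromatic carbon reaches further than the earlier pair showed: 4-(trifluoromethyl)phenyl gives a number 24.6 percentage points higher from compound 2 to compound 3 (beyond the scatter) and a number 42.1 percentage points higher from compound 1 to compound 3 (beyond the scatter) on the same shared core. The position thus clearly separates these three aryl groups, with 4-(trifluoromethyl)phenyl the highest of them. Nothing measured here accounts for this order. The compounds shown leave open whether the gain belongs to the trifluoromethyl group itself or to where it sits on the phenyl ring. 2-(Trifluoromethyl)phenyl, 4-fluorophenyl and 4-methoxyphenyl at this carbon would be the direct tests.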